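Chloro for Methoxy on a Second Pyrrolopyridine Core

The source may hold more compounds than are shown below. What is called first, only, known or untested is meant among the compounds shown, and "the series" means these compounds.

The series rests on two cores. Compound 1 `COc1ccc(-c2cc(C(=O)Nc3ccc(Oc4ccnc5[nH]ccc45)cc3)ncn2)cc1` and compound 2 `O=C(Nc1ccc(Oc2ccnc3[nH]ccc23)cc1)c1cc(-c2ccc(Cl)cc2)ncn1` share one of them; compound 3 `COc1ccc(-c2ccnc(C(=O)Nc3ccc(Oc4ccnc5[nH]ccc45)c(F)c3)n2)cc1` and the not yet measured compound 4 `O=C(Nc1ccc(Oc2ccnc3[nH]ccc23)c(F)c1)c1nccc(-c2ccc(Cl)cc2)n1` share the other. The difference between the two cores is not broken down here.

In a functional assay on PC-3 cells (Homo sapiens) for cytotoxicity, read by MTT assay, with a stated time of 72 h (a lower number here means a stronger inhibitor, a higher number a weaker inhibitor), compound 1 gives 9830 nM, compound 2 gives 15600 nM and compound 3 gives 14100 nM. All three numbers lie within the scatter of one another, so no order among them can be read from the data.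

The change from compound 1 to compound 2 is chloro in place of methoxy on an aromatic carbon. It made a 1.6-fold higher number from compound 1 to compound 2 (0.20 log units; within the scatter). The change from compound 3 to compound 4 is chloro in place of methoxy on an aromatic carbon. Its place is described in the same words as for the first pair, so it is the same change set on a different core; it occurs twice among the compounds shown.

Among the measured compounds shown here, with only one measured example of this change, the expectation for compound 4 leans on it. Compound 4 is expected to give 20000 nM in this assay, with a range of 10000 nM to 45000 nM, because compound 3 stands at 14100 nM and the earlier pair moved by a 1.6-fold higher number from compound 1 to compound 2 (0.20 log units; within the scatter). The estimated step is a 1.4-fold higher number from compound 3 to compound 4 (0.15 log units; within the scatter), which is expected to stay within the scatter, as the earlier one did.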

Compound 4, half-maximal inhibitory concentration: 14600 nM
For compound 4 the middle estimate is 1.4-fold (0.14 log units) above the measured one; low and high end bracket the measured number.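

In this assay, chloro in place of methoxy gave a 1.0-fold higher number from compound 3 to compound 4 (0.02 log units; within the scatter), so on the second core, as on the first, the change from 4-methoxyphenyl to 4-chlorophenyl stays within the scatter. The two steps can be read as agreeing, with no sign that the core alters what this change does: the same change on two cores in this assay, a 1.6-fold higher number (0.20 log units; within the scatter) from compound 1 to compound 2 and a 1.0-fold higher number (0.02 log units; within the scatter) from compound 3 to compound 4, 1.5-fold (0.19 log units) apart, within the scatter of two such steps. Among the compounds shown here, this shows only that on these two cores the swap has no effect that can be told from the scatter of repeated measurements; with just two pairs, neither step gives a reliable direction, and nothing follows about a third core or about compounds outside this set.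

The compounds shown leave open whether a different group on that aromatic carbon, such as an amine, a carboxylic acid or a longer alkoxy chain, would give a step beyond the scatter on either core. They also leave open what separates the two cores themselves, and whether the same agreement between the two pairs would hold in any readout other than this single cell assay.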